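Replacing 4-pentylphenyl with tert-butyl in compound 2

This account rests on a few compounds, and the source may have more. Where it says the series, first, only, none or still open, it means among the compounds named here.

In a functional assay on MCF7 cells (Homo sapiens) for antiproliferative activity, read by MTT assay, with a stated time of 72 h (a higher number here means a weaker inhibitor, a lower number a stronger inhibitor), compound 1 (`O=C1O[C@H]([C@@H](O)Cn2cc(-c3ccc(Br)cc3)nn2)C(OCc2ccccc2)=C1OCc1ccccc1`) gives 5620 nM and compound 2 (`CCCCCc1ccc(-c2cn(C[C@H](O)[C@H]3OC(=O)C(OCc4ccccc4)=C3OCc3ccccc3)nn2)cc1`) gives 9010 nM. These two values sit close together, with a 1.6-fold higher number from compound 1 to compound 2 (0.20 log units; within the scatter), which is within the scatter. Compound 3 (`CC(C)(C)OC(=O)N1CCN(C(=S)SCc2cn(C[C@H](O)[C@H]3OC(=O)C(OCc4ccccc4)=C3OCc3ccccc3)nn2)CC1`), which has no six-membered aromatic ring on that side of the shared core, is recorded only as a limit of the assay, > 100000 nM. Compound 4 (`CC(C)(C)c1cn(C[C@H](O)[C@H]2OC(=O)C(OCc3ccccc3)=C2OCc2ccccc2)nn1`) carries tert-butyl in place of the 4-pentylphenyl of compound 2: tert-butyl in place of 4-pentylphenyl on an aromatic carbon. For the measured compounds named here, the one measured step, a 1.6-fold higher number from compound 1 to compound 2 (0.20 log units; within the scatter), kept the aromatic ring that this change removes, so it offers only partial guidance. A modest move towards weaker inhibition is expected, an estimated 2.2-fold higher number from compound 2 to compound 4 (0.35 log units; beyond the scatter). For compound 4 the estimated value is 20000 nM, with an expected range of 6000 nM to 80000 nM.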

Compound 4, half-maximal inhibitory concentration: 730 nM
Compound 4: middle estimate off by 27-fold (1.44 log units), on the high side; the measured number lies below the stated range.
By their numbers in this assay, from the lowest: compound 4; then compounds 1 and 2 (each within the scatter of the next). At a limit, above all of these: compound 3.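

Swapping the whole 4-substituted phenyl group for tert-butyl matters far more at this position than changing the group on the phenyl ring, which left compound 1 and compound 2 within the scatter of each other. Tert-butyl gives a 12-fold lower number from compound 2 to compound 4 (1.09 log units; beyond the scatter) and a 7.7-fold lower number from compound 1 to compound 4 (0.89 log units; beyond the scatter). A six-membered aromatic ring on this carbon is therefore not required for activity in this assay.

Nothing measured here explains this gain. From the compounds shown here alone, whether methyl or cyclohexyl on this carbon would perform as well remains open.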